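This account rests on a few compounds, and the source may have more. Where it says the series, first, only, none or still open, it means among the compounds named here.

The series shares one core, carried by compound 1 `C[C@]1(CN2CCc3nc(C4CC4)ccc3C2)Cn2cc([N+](=O)[O-])nc2O1` and compound 2 `C[C@]1(CN2CCc3nc(C4CCOCC4)ccc3C2)Cn2cc([N+](=O)[O-])nc2O1`, both of which stand without a number in the test. In an ADME assay on Vero cells (Chlorocebus sabaeus) for cytotoxicity, read by MTT assay, with a stated time of 72 h (on this read-out higher numbers stand for lower toxicity in this test and lower numbers for higher toxicity in this test), compound 1 gives "not determined" (no result reported). In this assay compound 2 likewise gives "not determined" (no result reported). Compound 3 `C[C@]1(CN2CCc3nc(-c4ccc(F)c(Cl)c4)ccc3C2)Cn2cc([N+](=O)[O-])nc2O1` carries a 3-chloro-4-fluorophenyl group on an aromatic carbon of the core. In this assay compound 3 reaches only the limit of the test, > 32 ug/mL, which is a limit and not a number. Going by the values given here, this is where compound 3 stands: the limit of > 32 ug/mL in this assay, at which 1 of the 3 values shown sits, while the two other compounds give no single number, so no step between measured compounds can be drawn. Compound 4 `C[C@]1(CN2CCc3nc(-c4cc(F)c(F)c(F)c4)ccc3C2)Cn2cc([N+](=O)[O-])nc2O1` is the untested analogue; the change from compound 3 is 3,4,5-trifluorophenyl in place of 3-chloro-4-fluorophenyl on an aromatic carbon. Among the compounds with values here, with no measured step to lean on, the estimated a number no higher from compound 3 to compound 4 (the limit leaves the size open) in this assay is expected to lie within the scatter, in no set direction. Compound 4 is therefore expected to give about 32 ug/mL in this assay, between 16 ug/mL and 64 ug/mL, and most likely again only a limit.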

Compound 4, half-maximal cytotoxic concentration: > 32 ug/mL
Compound 4 ended at the assay's limit (the forecaster's own chance of this, stated with the estimate: 75%); the middle value lies on the limit itself.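

In this assay, no step can be read between compound 3 and compound 4, since both stop at a limit and not at a number: the limit of > 32 ug/mL in this assay, at which 2 of the 4 values shown sit.

The compounds shown leave open how far past that limit either compound lies, and whether 3,4,5-trifluorophenyl in place of 3-chloro-4-fluorophenyl changes the read-out at all.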